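Swapping amino for nitro on a cinnamamide benzophenone

This account rests on a few compounds, and the source may have more. Where it says the series, first, only, none or still open, it means among the compounds named here.

Measured so far:
- Compound 1 `COc1ccc(C(=O)c2cc(OC)c(OC)c(OC)c2)cc1NC(=O)/C=C/c1cccc(OC(F)(F)F)c1`: 7900 nM
- Compound 2 `COc1ccc(C(=O)c2cc(OC)c(OC)c(OC)c2)cc1NC(=O)/C=C/c1ccc(N)cc1`: 14700 nM

Both compounds share a core carrying a trimethoxy-substituted benzophenone and an amide linked through a double-bonded chain to a phenyl ring. In a functional assay on HeLa cells (Homo sapiens) for cytotoxicity, read by MTT assay, with a stated time of 72 h (a lower number here means a stronger inhibitor, a higher number a weaker inhibitor), compound 1 gives 7900 nM, and compound 2 gives 14700 nM. Compound 2 holds the highest of the two numbers, yet the step of a 1.9-fold higher number from compound 1 to compound 2 (0.27 log units; within the scatter) lies within the scatter, so the two cannot be ranked against each other.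

Compound 3 `COc1ccc(C(=O)c2cc(OC)c(OC)c(OC)c2)cc1NC(=O)/C=C/c1ccc([N+](=O)[O-])cc1` is not yet measured. It differs from compound 2 by nitro in place of amino on an aromatic carbon. Going by the values given here, no measured step touches this particular exchange; the single step on record, a 1.9-fold higher number from compound 1 to compound 2 (0.27 log units; within the scatter), changed a different ring substituent and stayed within the scatter. With nothing in the data pointing either way, the expected step of a 1.5-fold lower number from compound 2 to compound 3 (0.17 log units; within the scatter) is taken to be none beyond the scatter. Compound 3 is therefore estimated at 10000 nM in this assay, within a range from 3500 nM to 30000 nM.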

Compound 3, half-maximal inhibitory concentration: 8500 nM
The estimate for compound 3 lay 1.2-fold (0.07 log units) above the measured number; the measured number falls inside the stated range.
By their numbers in this assay, from the lowest: compounds 1, 3 and 2 (each within the scatter of the next).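

In this assay, putting nitro in place of amino on the aromatic carbon para to a large group gives a 1.7-fold lower number from compound 2 to compound 3 (0.24 log units; within the scatter). Going by these compounds alone, this is the first direct reading at this position: amino brings a hydrogen-bond donor and nitro brings none, and nitro also has more heavy atoms, yet the two compounds cannot be told apart in this cell test. The other new comparison, 4-nitrophenyl in place of 3-(trifluoromethoxy)phenyl, gives a 1.1-fold higher number from compound 1 to compound 3 (0.03 log units; within the scatter), so all three compounds shown lie within the scatter of one another and no ranking among them can be drawn, while no measured evidence is available to explain the result.

The compounds shown leave open whether any group on this aromatic carbon can move the number beyond the scatter, for example a carboxylic acid, a hydroxyl or a longer chain such as butoxy. They also leave open how a bare phenyl ring, with no group on it at all, would compare with these three.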